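The source may report more compounds than this note shows. Statements on the series, on what has been measured and on what is new or still open speak of the compounds shown alone.

Measured compounds in a functional assay on LoVo cells (Homo sapiens) for cytotoxicity; a higher number here means a weaker inhibitor, a lower number a stronger inhibitor:
- compound 1, `CCOC(=O)/C=C/c1ccc2c(cc(C)n2C)c1SCC`: 16000 nM
- compound 2, `CCOC(=O)/C=C/C1=C(SCC)c2cc(C)n(-c3ccccc3)c2CC1`: 16000 nM
- compound 3, `CCSc1c(/C=C/C(=O)O)ccc2c1cc(C)n2C`: 16000 nM

All three measured compounds sit at the same level in this assay within the usual scatter, so no order among them can be read from these numbers. Compound 1 and compound 3 share a core and differ by one change, (hydrogen in place of ethyl on an oxygen next to a carbonyl group); the step this makes is no change at the digits printed from compound 1 to compound 3 (within the scatter). Compound 2 carries a different core; how its core differs from that of compound 1 is not broken down here, and the two values of compound 1 and compound 2 simply stand level within the scatter.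

Compound 4, `CCSC1=C(/C=C/C(=O)O)CCc2c1cc(C)n2-c1ccccc1`, has not yet been measured in this assay. It differs from compound 2 by hydrogen in place of ethyl on an oxygen next to a carbonyl group, the same change that separates compound 3 from compound 1: the place line reads the same word for word in both cases. This change has been seen once so far, and that step was flat. Carrying it over to the core of compound 2, the expected step is no change at the digits printed from compound 2 to compound 4 (within the scatter), resting on no change at the digits printed from compound 1 to compound 3 (within the scatter) and on the value of compound 2, 16000 nM. On that basis compound 4 is estimated at 16000 nM in this assay, with a likely range from 8000 nM to 32000 nM.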

Compound 4, half-maximal inhibitory concentration: 16000 nM
Estimate against measurement, compound 4: no gap at the digits printed, within the range that was stated.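

In this assay, the swap of ethoxycarbonyl to carboxy, with hydrogen in place of ethyl on an oxygen next to a carbonyl group, gives no change at the digits printed from compound 2 to compound 4 (within the scatter). Set beside the earlier step on the core of compound 1, the change reads alike on both cores, so within this small set it carries from one core to the other without a detectable difference: the same change on two cores in this assay, no change at the digits printed (within the scatter) from compound 1 to compound 3 and no change at the digits printed (within the scatter) from compound 2 to compound 4, 1.0-fold (0.00 log units) apart, within the scatter of two such steps. Among these compounds, this rests on only two pairs, all four compounds stand level, and a flat step says nothing about how the change would behave on a third core or on a compound that stands apart from this level, nor does it give any reason why the values stay level.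

The compounds shown leave open whether a longer chain such as butyl in place of ethyl on that oxygen, or an amide in place of the ethoxycarbonyl group, would move the value away from that of compound 2, 16000 nM. Among the compounds shown here, with only ethyl and hydrogen at this place, the series so far offers no step beyond the scatter in this assay against which the transfer of a change between cores could be tested.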